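A few compounds are considered here, and "the series" means these few. Any claim that something is new, unique, unknown or untested is made for them only; others in the source may bear on it.

Measured compounds:
Compound 1 `COc1cc(OC)c(/C=C/S(=O)(=O)Cc2ccc(OC)c(N)c2)c(OC)c1`: 4 nM
Compound 2 `COc1ccc(CS(=O)(=O)/C=C/c2c(OC)cc(O)cc2OC)cc1N`: 200 nM
Compound 3 `COC(=O)CNc1cc(CS(=O)(=O)/C=C/c2cc(OC)c(OC)c(OC)c2)ccc1OC`: 75000 nM

In a functional assay on DU-145 cells (Homo sapiens) for cytotoxicity, read by trypan blue exclusion, with a stated time of 96 h (a higher number here means a weaker inhibitor, a lower number a stronger inhibitor), compound 1 gives 4 nM, the lowest of the three numbers. Compound 2 differs from compound 1 by hydrogen in place of methyl on an oxygen on an aromatic ring; the step is a 50-fold higher number from compound 1 to compound 2 (1.70 log units; beyond the scatter). Compound 3 gives 75000 nM in this assay, the highest of the three numbers; how its core differs from that of compound 1 is not broken down here.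

Compound 4 `COc1ccc(CS(=O)(=O)/C=C/c2cc(OC)c(OC)c(OC)c2)cc1NCC(=O)O` is not yet measured. It differs from compound 3 by hydrogen in place of methyl on an oxygen next to a carbonyl group. This is the same kind of change as from compound 1 to compound 2, but not the same: there the place was on an oxygen on an aromatic ring whose other neighbours are an aromatic carbon, here it is on an oxygen next to a carbonyl group whose other neighbours are the carbonyl carbon. The earlier step therefore gives only a loose guide. Because compound 3 already sits at 75000 nM, the change is expected to leave the number high or raise it further, an expected step of a 1.3-fold higher number from compound 3 to compound 4 (0.12 log units; within the scatter). Compound 4 is estimated at 100000 nM in this assay, between 30000 nM and 300000 nM.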

Compound 4, half-maximal inhibitory concentration: 5000 nM
Compound 4: middle estimate off by 20-fold (1.30 log units), on the high side; the measured number lies below the stated range.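

In this assay, the step of a 15-fold lower number from compound 3 to compound 4 (1.18 log units; beyond the scatter) runs in the opposite direction to the earlier step of the same kind, so replacing methyl with hydrogen on an oxygen does not carry as a fixed shift from one core to another in this series: the same change on two cores in this assay, a 50-fold higher number (1.70 log units; beyond the scatter) from compound 1 to compound 2 and a 15-fold lower number (1.18 log units; beyond the scatter) from compound 3 to compound 4, 750-fold (2.88 log units) apart, beyond the scatter of two such steps

The two steps differ in both place and core, one on an oxygen on an aromatic ring and the other on an oxygen next to a carbonyl group, so this pair cannot show whether place or core accounts for the gap. Nor does it show a rule for either place, since each place is represented by a single step on a single core.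

As far as these compounds go, it remains open how methoxy to hydroxy would read on the core of compound 3, and how methoxycarbonyl to carboxy would read on a core closer to that of compound 1. Also open, from the compounds shown here alone, is how an ethyl ester, a primary amide or a longer chain ending in a carboxylic acid would compare with the carboxymethyl group of compound 4 in this assay.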